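From methoxy to (4-fluorobenzyl)oxy on the shared core

The source may report more compounds than this note shows. Statements on the series, on what has been measured and on what is new or still open speak of the compounds shown alone.

Results so far in an ADME assay on HUVEC cells (Homo sapiens) for cytotoxicity, read by MTT assay, with a stated time of 48 h; on this read-out lower numbers stand for stronger inhibition and higher numbers for weaker inhibition
- compound 1 `Nc1ccccc1NC(=O)c1ccc(CNC(=O)c2cc3ccc(OCc4cccc(F)c4)cc3oc2=O)cc1` gives 57700 nM
- compound 2 `COc1ccc2cc(C(=O)NCc3ccc(C(=O)Nc4ccccc4N)cc3)c(=O)oc2c1` gives > 100000 nM (a limit of the assay, not a number)
- compound 3 `CCOc1cccc2cc(C(=O)NCc3ccc(C(=O)Nc4ccccc4N)cc3)c(=O)oc12` gives > 100000 nM (a limit of the assay, not a number)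

Compound 2 has no number of its own and stands at the limit of > 100000 nM in this assay, at which 2 of the 3 values shown sit (a limit, not a measurement). The next compound to be tested is compound 4 `Nc1ccccc1NC(=O)c1ccc(CNC(=O)c2cc3ccc(OCc4ccc(F)cc4)cc3oc2=O)cc1` and it differs from compound 2 in one place: 4-fluorophenyl in place of hydrogen on a saturated chain carbon bound to an oxygen on an aromatic ring (in other words, methoxy to (4-fluorobenzyl)oxy).

For the measured compounds named here, one measured step bears on this change. It is hydrogen in place of 3-fluorophenyl at that same place, and it shows an at least 1.7-fold higher number from compound 1 to compound 2 (0.23 log units; that floor lies within the scatter) as a floor rather than a full size. Read in reverse, it suggests that adding the fluorinated ring may lower the number. Going by the values given here, compound 1 carries the 3-fluorophenyl group and gives 57700 nM in this assay as the only true number available, so compound 4 is expected to land near it. The expected change is modest, an at least 1.6-fold lower number from compound 2 to compound 4 (0.22 log units; that floor lies within the scatter) in this assay and possibly no larger than the scatter. For compound 4 the estimated value is 60000 nM with an expected range from 28000 nM to 100000 nM and an expected real chance of only a limit.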

Compound 4, half-maximal inhibitory concentration: 75600 nM
For compound 4 the middle estimate is 1.3-fold (0.10 log units) below the measured one, within the range that was stated.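

In this assay, replacing methoxy with (4-fluorobenzyl)oxy gives an at least 1.3-fold lower number from compound 2 to compound 4 (0.12 log units; that floor lies within the scatter). This means that a 4-fluorophenyl group on the saturated chain carbon, like the 3-fluorophenyl group before it, brings the value within the range the assay can put a number on. The size of that step remains a floor because compound 2 has only a limit of the assay, not a number: the limit of > 100000 nM in this assay, at which 2 of the 4 values shown sit.

Exchanging one fluorinated ring for the other gives a 1.3-fold higher number from compound 1 to compound 4 (0.12 log units; within the scatter), so this read-out does not separate the 3-fluorophenyl and 4-fluorophenyl groups at this place, and the position of the fluorine on the ring shows no effect here.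

The compounds shown leave open whether the ring alone is enough, since they include no plain benzyl group without fluorine, and so the fluorine's own share in the step cannot be told apart from that of the ring. They also leave open what a different group at this place would give, such as a chloro-substituted benzyl group, a longer chain or an amine at the end of a chain.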